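A few compounds are considered here, and "the series" means these few. Any claim that something is new, unique, unknown or untested is made for them only; others in the source may bear on it.

Among the measured compounds shown here, compound 1, `CC(C)Nc1nc(O)c2cc(Cl)ccc2n1`, is one of two compounds measured in a functional assay on the whole organism (uterus) with Rattus norvegicus as the target, tested at 50 uM; on this read-out lower numbers stand for a stronger effect and higher numbers for a weaker effect at the one concentration tested. In this assay compound 1 gives 61%. Compound 2, `C[C@H](Nc1nc(O)c2cc(Cl)ccc2n1)c1ccccc1`, is the other; in this assay compound 2 gives 44.9%. On these two numbers compound 1 stands highest, and compound 2 sits below it by an amount that goes beyond the usual scatter of repeated measurements, so compound 2 shows the stronger effect of the two at the single concentration tested.

Compound 3, `CC(C)Nc1nc(O)c2cc(I)ccc2n1`, has not yet been measured in this assay. It differs from compound 1 in one place: iodo in place of chloro on an aromatic carbon. The core and the isopropylamino group are untouched; only the substituent on the aromatic carbon changes.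

For the measured compounds named here, no measured pair shows what this kind of swap does in this assay. With nothing to go on beyond the two values above and the small size of the change, a step from compound 1 to compound 3 is expected to stay within the scatter, in either direction, as a number 3 percentage points lower from compound 1 to compound 3 (within the scatter) expresses. Compound 3 is therefore expected to give about 58% in this assay, with a range from 40% to 76%.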

Compound 3, a percentage reported as activity, at one concentration (the size of the read-out at that concentration, not a potency): 41%
Beside the measured number, compound 3's estimate is 17 percentage points above it; the range from low to high includes it.
By their numbers in this assay, from the lowest: compounds 3 and 2 (each within the scatter of the next); then compound 1.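

In this assay, the aromatic carbon that carries the halogen proves responsive: iodo in place of chloro gives a number 20 percentage points lower from compound 1 to compound 3 (beyond the scatter). Among the compounds shown here, this is the first measured step at this place, which is meta to a fused ring and para to a fused ring, and it shows that exchanging a single heavy atom can move the read-out beyond the scatter towards a stronger effect. The core and the isopropylamino group are the same in both compounds, and this one swap is the only difference between them. For the compounds shown here, the step is seen for only one pair and at only one concentration. Nothing measured here bears on what lies behind the step.

The compounds shown leave open how bromo, fluoro, or a methoxy group would behave on this aromatic carbon, so it cannot yet be said whether the step is particular to iodo or part of a wider trend. Going by these compounds alone, they also leave open whether iodo in place of chloro would give a similar step when the amino group is the one carried by compound 2.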